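From 4-chlorobenzyl to cyclohexylcarbonyl on an amine nitrogen

The source may hold more compounds than are shown below. What is called first, only, known or untested is meant among the compounds shown, and "the series" means these compounds.

Compound 1 `C[C@H](NC(=O)[C@H](C)[C@H]1CC[C@@H](c2ccnc3ccc(F)cc32)CC1)c1ccc(Cl)cc1` gives 5%
Compound 2 `C[C@@H](NCc1ccc(Cl)cc1)[C@H]1CC[C@@H](c2ccnc3ccc(F)cc32)CC1` gives 2%
Compound 3 `C[C@@H](c1nc2ccc(Cl)cc2[nH]1)[C@H]1CC[C@@H](c2ccnc3ccc(F)cc32)CC1` gives 12%

These values come from an ADME assay on microsomes from liver (Mus musculus) for metabolic stability, with a stated time of 10 min, tested at 0.5 uM (on this read-out lower numbers stand for a less stable compound and higher numbers for a more stable compound), and lie within the usual scatter of one another, so compound 2 at 2% cannot be told apart from the other two. Compound 4 `C[C@@H](NC(=O)C1CCCCC1)[C@H]1CC[C@@H](c2ccnc3ccc(F)cc32)CC1` has cyclohexylcarbonyl in place of 4-chlorobenzyl on an amine nitrogen and has not yet been measured. Within the data shown here, no pair of measured compounds differs in one place, so nothing shows this change directly. Compound 1 at 5% and compound 3 at 12% carry other groups on the shared core, yet neither stands apart from compound 2. The expected a number 7 percentage points higher from compound 2 to compound 4 (within the scatter) is therefore small, slightly upward and within the scatter. For compound 4 the estimated value is 9%, with an expected range from 2% to 28%.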

Compound 4, percent of the compound remaining: 5%
Estimate against measurement, compound 4: 4 percentage points above, within the range that was stated.
By their numbers in this assay, from the lowest: compounds 2, 1, 4 and 3 (each within the scatter of the next).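

In this assay, among these compounds, the first comparison that differs in one place shows that putting cyclohexylcarbonyl in place of 4-chlorobenzyl on an amine nitrogen gives a number 3 percentage points higher from compound 2 to compound 4 (within the scatter). An aromatic ring bearing chlorine and a non-aromatic ring bearing a carbonyl, with the same number of heavy atoms, therefore cannot be told apart at this position. Nothing measured here bears on why. From the compounds shown here alone, whether acetyl or a longer chain on this nitrogen would move the number beyond the scatter stays open. So does whether a change elsewhere on the shared core would do so.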